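Replacing carboxy(difluoro)methyl with carboxy(phenyl)methyl

The source may hold more compounds than are shown below. What is called first, only, known or untested is meant among the compounds shown, and "the series" means these compounds.

Measured in a functional assay on DU-145 cells (Homo sapiens) for cytotoxicity, read by trypan blue exclusion, with a stated time of 96 h (on this read-out higher numbers stand for weaker inhibition and lower numbers for stronger inhibition), compound 1 `COC(=O)CNc1cc(CS(=O)(=O)/C=C/c2c(OC)cc(OC)cc2OC)ccc1OC` gives 100 nM and compound 2 `COC(=O)C(Nc1cc(CS(=O)(=O)/C=C/c2c(OC)cc(OC)cc2OC)ccc1OC)c1ccccc1` gives 75 nM while compound 3 `COc1cc(OC)c(/C=C/S(=O)(=O)Cc2ccc(OC)c(NC(F)(F)C(=O)O)c2)c(OC)c1` gives 150 nM so compound 3 lies within the usual scatter of both others. Compound 4 `COc1cc(OC)c(/C=C/S(=O)(=O)Cc2ccc(OC)c(NC(C(=O)O)c3ccccc3)c2)c(OC)c1` carries carboxy(phenyl)methyl in place of carboxy(difluoro)methyl on a nitrogen on an aromatic ring. Among the compounds with values here, three measured steps bear on this change. Phenyl in place of hydrogen gave a 1.3-fold lower number from compound 1 to compound 2 (0.12 log units; within the scatter) and leaving the phenyl-bearing group for carboxy(difluoro)methyl gave a 2.0-fold higher number from compound 2 to compound 3 (0.30 log units; within the scatter) while a 1.5-fold higher number from compound 1 to compound 3 (0.18 log units; within the scatter) completes the set. None exceeds the scatter, so the expected step in this assay is a 1.5-fold lower number from compound 3 to compound 4 (0.18 log units; within the scatter) with no clear shift in either direction. For compound 4 the estimate is 100 nM with an expected range from 40 nM to 300 nM around it.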

Compound 4, half-maximal inhibitory concentration: 20 nM
The estimate for compound 4 lay 5.0-fold (0.70 log units) above the measured number; measured number outside the range, below it.
By their numbers in this assay, from the lowest: compound 4; then compounds 2, 1 and 3 (each within the scatter of the next).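

Within the data shown here, at this nitrogen on an aromatic ring, carboxy(phenyl)methyl gives the first steps beyond the scatter in this assay: a 7.5-fold lower number from compound 3 to compound 4 (0.88 log units; beyond the scatter), a 3.8-fold lower number from compound 2 to compound 4 (0.57 log units; beyond the scatter) and a 5.0-fold lower number from compound 1 to compound 4 (0.70 log units; beyond the scatter). The group on this nitrogen can therefore change the result, although phenyl in place of hydrogen on the methyl ester stayed within the scatter, and the clear shift appears only with phenyl and the free carboxylic acid together. No measurement shown explains this shift.

Carboxymethyl on this nitrogen lies outside the compounds shown, so the part played by the phenyl alone stays open. So does the result of a primary amide in place of the carboxylic acid.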